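This account rests on a few compounds, and the source may have more. Where it says the series, first, only, none or still open, it means among the compounds named here.

Compound 1 `CCCCCCCCCCCCCCC(COCc1ccccc1)NCC` and compound 2 `CCCCCCCCCCCCCCC(COCc1ccccc1)NC(=O)CCCC(=O)OC` share the same core and differ only on an amine nitrogen. In an ADME assay on cells (Splenocyte, Mus musculus, strain BALB/c) for cytotoxicity, read by MTT assay, tested at 10 ug/mL (on this read-out higher numbers stand for a stronger effect at the one concentration tested and lower numbers for a weaker effect), compound 1 gives 11.9%, and compound 2 gives 2.5%; the step of a number 9.4 percentage points lower from compound 1 to compound 2 (within the scatter) leaves the two values within the usual scatter of each other, so compound 2 stands alongside compound 1 rather than apart from it. Compound 3 `CCCCCCCCCCCCCCC(COCc1ccccc1)NC(=O)CCCC(=O)O` differs from compound 2 by hydrogen in place of methyl on an oxygen next to a carbonyl group. Going by the values given here, no measured step touches this position, so nothing in the data points to a shift beyond the scatter. Compound 3 is therefore expected to give about 4%, between 0% and 14%. The step of a number 1.5 percentage points higher from compound 2 to compound 3 (within the scatter) that this estimate implies is expected to stay within the scatter.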

Compound 3, a percentage reported as activity, at one concentration (the size of the read-out at that concentration, not a potency): 6.4%
Estimate against measurement, compound 3: 2.4 percentage points below, and the stated range covers the measured number.
By their numbers in this assay, from the lowest: compounds 2, 3 and 1 (each within the scatter of the next).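

Replacing methyl with hydrogen on an oxygen next to a carbonyl group, which turns methoxycarbonyl into carboxy, gives a number 3.9 percentage points higher from compound 2 to compound 3 (within the scatter) in this assay, so this change does not set the two compounds apart. Placing (3-carboxypropyl)carbonyl instead of ethyl on an amine nitrogen gives a number 5.5 percentage points lower from compound 1 to compound 3 (within the scatter), so the carboxy form also stands alongside compound 1. Nothing available explains these numbers. On these data alone, whether an ethyl ester or a primary amide in place of the carboxy group, or a longer chain on the amine nitrogen, would give a number beyond the scatter remains open.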